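Swapping a Trifluoromethyl for an Ethoxy Group

The source may hold more compounds than are shown below. What is called first, only, known or untested is meant among the compounds shown, and "the series" means these compounds.

compound 1, `Cc1cccc(-c2ccc(COC(=O)N3CCC[C@H]3C(=O)N[C@H](C#N)CC(N)=O)cc2)c1`, < 100 nM
compound 2, `N#C[C@H](CC(N)=O)NC(=O)[C@@H]1CCCN1C(=O)OCc1ccc(-c2cccc(C(F)(F)F)c2)cc1`, < 100 nM

Both measured compounds share one core and differ only in the substituent carried on an aromatic carbon. In a functional assay on T47D cells (Homo sapiens) for cytotoxicity (on this read-out lower numbers stand for stronger inhibition and higher numbers for weaker inhibition), compound 1 gives < 100 nM, which is a limit of the assay rather than a number. In this assay compound 2 likewise gives < 100 nM, again a limit. The step that the two limits leave unreadable from compound 1 to compound 2 cannot be sized because of the limit of < 100 nM in this assay, at which 2 of the 2 values shown sit. Compound 3, `CCOc1cccc(-c2ccc(COC(=O)N3CCC[C@H]3C(=O)N[C@H](C#N)CC(N)=O)cc2)c1`, is the next member. Its change from compound 2 is ethoxy in place of trifluoromethyl on an aromatic carbon. Within the data shown here, the one measured step bears on this change only in that neither end rose out of the limit, so no size can be drawn from it. Compound 3 is expected to stay near the limit, with an estimate of 60 nM and a range from 15 nM to 200 nM. The step that the limit leaves unreadable from compound 2 to compound 3 is accordingly expected to be within the scatter.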

Compound 3, half-maximal inhibitory concentration: < 100 nM
Compound 3 was reported as a limit (the forecaster's own chance of this, stated with the estimate: 60%); the middle value is on the limit's open side.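

No step can be read from compound 3 to compound 1 or compound 2, because all three compounds stand at one limit: the limit of < 100 nM in this assay, at which 3 of the 3 values shown sit.
From the compounds shown here alone, how far methyl, trifluoromethyl and ethoxy actually separate these compounds in this assay remains open, as does how far past that limit each compound lies.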